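From Propylsulfanyl to Butoxy on a Shared Core

This account rests on a few compounds, and the source may have more. Where it says the series, first, only, none or still open, it means among the compounds named here.

In a functional assay on MV4-11 cells (Homo sapiens) for inhibition, read by resazurin assay, with a stated time of 72 h (on this read-out lower numbers stand for stronger inhibition of growth and higher numbers for weaker inhibition of growth), compound 3 `CCCSc1nc(C)c(-c2ccnc(Nc3ccc(OC)cc3OC)n2)s1` gives 2240 nM, the second highest of the three numbers measured. Compound 1 `COc1ccc(Nc2nccc(-c3sc(SC(C)C)nc3C)n2)c(OC)c1` stands higher at 5670 nM, and compound 2 `COc1ccc(Nc2nccc(-c3sc(N(C)C)nc3C)n2)c(OC)c1` stands lower at 170 nM. Compound 4 `CCCCOc1nc(C)c(-c2ccnc(Nc3ccc(OC)cc3OC)n2)s1` has not yet been measured. It carries butoxy in place of propylsulfanyl on an aromatic carbon. For the measured compounds named here, no measured step makes this exchange, and no measured compound carries butoxy. The closest evidence is a 2.5-fold lower number from compound 1 to compound 3 (0.40 log units; beyond the scatter), a modest step for propyl in place of isopropyl on a sulfur. Two large steps, a 33-fold lower number from compound 1 to compound 2 (1.52 log units; beyond the scatter) and a 13-fold higher number from compound 2 to compound 3 (1.12 log units; beyond the scatter), show that the group at this place can matter, but both involve dimethylamino, which compound 4 lacks. They give no direction for butoxy, so no step beyond the scatter is expected in this assay, though the uncertainty is wide. The estimated change is a 1.1-fold lower number from compound 3 to compound 4 (0.05 log units; within the scatter). For compound 4 the estimated value is 2000 nM, with an expected range from 600 nM to 6000 nM.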

Compound 4, concentration for 50% growth inhibition: 7860 nM
For compound 4 the middle estimate is 3.9-fold (0.59 log units) below the measured one, and the stated range ends below it.
By their numbers in this assay, from the lowest: compound 2; then compound 3; then compounds 1 and 4 (each within the scatter of the next).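

In this assay, for the compounds shown here, butoxy in place of propylsulfanyl gives a 3.5-fold higher number from compound 3 to compound 4 (0.55 log units; beyond the scatter), so at this place a chain joined through oxygen does not match propylsulfanyl, a change the earlier steps did not test. Butoxy also stands far from the amine, with a 46-fold higher number from compound 2 to compound 4 (1.66 log units; beyond the scatter), while a 1.4-fold higher number from compound 1 to compound 4 (0.14 log units; within the scatter) gives no order between butoxy and isopropylsulfanyl. Dimethylamino therefore remains the only group here with a large step to each of the other three.

From the compounds shown here alone, this exchange alters the linking atom and the chain together, so propoxy or butylsulfanyl would be needed to separate the two changes, and it remains open whether other amines, such as morpholine or pyrrolidine, behave like dimethylamino. Nothing available accounts for these differences in growth inhibition.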